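A few compounds are considered here, and "the series" means these few. Any claim that something is new, unique, unknown or untested is made for them only; others in the source may bear on it.

For the measured compounds named here, in an assay for binding affinity to 5-hydroxytryptamine receptor 1D (Homo sapiens), read by radioligand binding (on this read-out lower numbers stand for stronger inhibition and higher numbers for weaker inhibition), compound 1 `CN1CCC(c2c[nH]c3ccc(NC(=O)C4CC4)nc23)CC1` gives 1800 nM, and compound 2 `Cc1cccc(C(=O)Nc2ccc3[nH]cc(C4CCN(C)CC4)c3n2)c1` gives 490 nM, the lowest of the two numbers so far. Going by the values given here, the only measured step, a 3.7-fold lower number from compound 1 to compound 2 (0.57 log units; beyond the scatter), put a six-membered aromatic ring of carbon only on the carbonyl carbon in place of cyclopropyl. Compound 3 `CN1CCC(c2c[nH]c3ccc(NC(=O)c4ccc([N+](=O)[O-])cc4)nc23)CC1` keeps such a ring there but alters it: 4-nitrophenyl in place of 3-methylphenyl on a carbonyl carbon. Among the compounds with values here, no measured step exchanges one such ring for another, so guidance is indirect; the change is expected to move the number little, within or near the scatter, in either direction. Compound 3 is therefore expected near 600 nM, within 200 nM to 2000 nM. The step of a 1.2-fold higher number from compound 2 to compound 3 (0.09 log units; within the scatter) is expected to stay small.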

Compound 3, inhibition constant: 340 nM
Beside the measured number, compound 3's estimate is 1.8-fold (0.25 log units) above it; measured number inside the range.
By their numbers in this assay, from the lowest: compounds 3 and 2 (each within the scatter of the next); then compound 1.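

In this assay the swap of 3-methylphenyl for 4-nitrophenyl on the carbonyl carbon gives a 1.4-fold lower number from compound 2 to compound 3 (0.16 log units; within the scatter), so the two substituted rings cannot be told apart at this position. The lower number seen against cyclopropyl recurs with this second ring, at a 5.3-fold lower number from compound 1 to compound 3 (0.72 log units; beyond the scatter). Nothing available bears on the reason for either step. Still open, going by these compounds, is whether unsubstituted phenyl, a pyridyl ring or an amine on the ring would hold the number at this level, and whether the position of the ring substituent matters.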